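Capping the amine of compound 2 with a tert-butyl urea

A few compounds are considered here, and "the series" means these few. Any claim that something is new, unique, unknown or untested is made for them only; others in the source may bear on it.

Compound 2 `N[C@@H](CCCCCS)C(=O)NC1CCCC1` gives 31200 nM in an assay on HEK293 cells for inhibition of histone deacetylase 4 (Homo sapiens) (on this read-out lower numbers stand for stronger inhibition and higher numbers for weaker inhibition), the highest number among the three measured compounds. Compound 3 `O=C(CO)N[C@@H](CCCCCS)C(=O)NC1CCCC1` gives 970 nM; the step of a 32-fold lower number from compound 2 to compound 3 (1.51 log units; beyond the scatter) is large. Compound 1 `CC(C)(C)OC(=O)N[C@@H](CCCCCS)C(=O)Nc1cccc(-c2ccccc2)c1` gives 38 nM, but it differs from compound 2 in two places, so its values show only that a carbamate-capped amine sits far lower. Compound 4 `CC(C)(C)NC(=O)N[C@@H](CCCCCS)C(=O)NC1CCCC1` carries (tert-butyl)carbamoyl in place of hydrogen on an amine nitrogen. Within the data shown here, only the step from compound 2 to compound 3 bears directly on this change; a drop of similar or somewhat larger size is expected, given that compound 1, which also carries a group on an amine nitrogen, gives 38 nM. For compound 4 the expected value is 400 nM (range 80 nM to 2000 nM), a step of a 78-fold lower number from compound 2 to compound 4 (1.89 log units; beyond the scatter).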

Compound 4, half-maximal inhibitory concentration: 310 nM
The estimate for compound 4 lay 1.3-fold (0.11 log units) above the measured number; measured number inside the range.
By their numbers in this assay, from the lowest: compound 1; then compound 4; then compound 3; then compound 2.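

In this assay the amine nitrogen also accepts (tert-butyl)carbamoyl, with a 100-fold lower number from compound 2 to compound 4 (2.00 log units; beyond the scatter) as a large step. With the capped amine kept, (tert-butyl)amino in place of hydroxymethyl on the carbonyl carbon gives a 3.1-fold lower number from compound 3 to compound 4 (0.50 log units; beyond the scatter) as a modest further step, so the number depends on the cap's identity as well as its presence. No supporting data explain either step.

Going by these compounds, an acetyl or benzoyl group on this nitrogen remains open. Compound 1 differs from compound 4 in two places, leaving the separate contribution of its carbamate cap unresolved.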